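The compounds below may be only part of what the source reports. "The series", "measured", "known", "first", "only" and "open" are said of these compounds alone.

For the measured compounds named here, in a functional assay on HL-60 cells (Homo sapiens) for antiproliferative activity, read by MTT assay, with a stated time of 6 days (a higher number here means a weaker inhibitor, a lower number a stronger inhibitor), only two compounds have numbers so far. Compound 1 `CC(=O)O[C@@H]1C=CC(=O)O[C@@H]1[C@@H](COC(=O)c1ccc(Cl)cc1)OC(C)=O` gives 32600 nM, the higher number of the two and so the weaker inhibitor. Compound 2 `O=C1C=C[C@@H](OCc2ccccc2)[C@@H]([C@@H](COC(=O)/C=C/c2ccc(F)cc2)OCc2ccccc2)O1` gives 5400 nM, and the gap between them lies beyond the usual scatter of repeat measurements.

The next compound, compound 3 `CC(=O)OC[C@@H](OC(C)=O)[C@H]1OC(=O)C=C[C@H]1OC(C)=O`, is compound 1 with one change: methyl in place of 4-chlorophenyl on a carbonyl carbon. Read one bond further out, (4-chlorophenyl)carbonyl becomes acetyl and the aromatic ring is gone.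

Going by the values given here, no two measured compounds differ in just one place, so nothing yet measures this change directly. Among the compounds with values here, the only guide is slender: compound 1 and compound 2 both carry an aromatic ring, while compound 3 carries none. On that basis a small rise in the number is expected, perhaps one that stays within the scatter. The expected change is a 1.4-fold higher number from compound 1 to compound 3 (0.14 log units; within the scatter). For compound 3 the estimated value is 45000 nM, with an expected range from 13000 nM to 150000 nM.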

Compound 3, half-maximal inhibitory concentration: 29700 nM
Estimate against measurement, compound 3: 1.5-fold (0.18 log units) above; the range from low to high includes it.
By their numbers in this assay, from the lowest: compound 2; then compounds 3 and 1 (each within the scatter of the next).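

In this assay, for the compounds shown here, putting methyl in place of 4-chlorophenyl on a carbonyl carbon gives a 1.1-fold lower number from compound 1 to compound 3 (0.04 log units; within the scatter), and this is the first direct reading of any single change. The step lies within the scatter, so compound 1 and compound 3 cannot be told apart in this assay, even though the swap removes the whole aromatic ring along with its chlorine. On the shared core, then, the 4-chlorophenyl group is not required for the level of antiproliferative activity that compound 1 shows, and a group as small as methyl serves equally well at this position. Nothing measured on these compounds speaks to why the number stays put when the ring is removed.

Going by these compounds, only methyl and 4-chlorophenyl have been compared at this position, so it remains open whether a longer alkyl chain, an amine or a carboxylic acid on the same carbonyl carbon would move the number beyond the scatter. On these data alone, it also remains open whether the same swap would prove as silent on a compound that starts from a lower number.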